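A few compounds are considered here, and "the series" means these few. Any claim that something is new, unique, unknown or untested is made for them only; others in the source may bear on it.

Measured so far in a functional assay on SK-OV-3 cells (Homo sapiens) for antiproliferative activity, read by MTT assay, with a stated time of 72 h; on this read-out lower numbers stand for stronger inhibition and higher numbers for weaker inhibition:

compound 1 `O=C(CCc1cccc2c1B(O)OC2)Nc1ccc(Cl)cc1` gives 5000 nM
compound 2 `COc1ccc(NC(=O)CCc2cccc3c2B(O)OC3)cc1` gives 900 nM
compound 3 `O=C(CCc1cccc2c1B(O)OC2)Nc1cccc(-c2ccc(Cl)cc2)c1` gives 220 nM

Compound 3 carries the lowest number of the three. The difference between the core of compound 1 and the core of compound 3 is not broken down here. Between compound 1 and compound 2 the change is methoxy in place of chloro on an aromatic carbon and it produced a 5.6-fold lower number from compound 1 to compound 2 (0.74 log units; beyond the scatter) in this assay. Compound 4 `COc1ccc(-c2cccc(NC(=O)CCc3cccc4c3B(O)OC4)c2)cc1` has not yet been measured; it differs from compound 3 by methoxy in place of chloro on an aromatic carbon, the same change as the one already seen, at the same place. Going by the values given here, compound 4 is expected to show a 2.8-fold lower number from compound 3 to compound 4 (0.44 log units; beyond the scatter) in this assay, a smaller step than the earlier one, because only one pair, compound 1 to compound 2 with a 5.6-fold lower number from compound 1 to compound 2 (0.74 log units; beyond the scatter), supports the direction. The estimate for compound 4 is 80 nM, between 25 nM and 250 nM.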

Compound 4, half-maximal inhibitory concentration: 48 nM
Compound 4: middle estimate off by 1.7-fold (0.22 log units), on the high side; the measured number falls inside the stated range.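

In this assay, methoxy in place of chloro again gave a lower number, with a 4.6-fold lower number from compound 3 to compound 4 (0.66 log units; beyond the scatter). Set beside the earlier step, the change carried over from one core to the other at much the same size: the same change on two cores in this assay, a 5.6-fold lower number (0.74 log units; beyond the scatter) from compound 1 to compound 2 and a 4.6-fold lower number (0.66 log units; beyond the scatter) from compound 3 to compound 4, 1.2-fold (0.08 log units) apart, within the scatter of two such steps. These two pairs show that the step held on these two cores, but they do not show that it would hold on any other core, nor why it occurs.

The compounds shown leave open how other groups at the same place, such as ethoxy, hydroxyl or an amine, would compare with methoxy. Going by these compounds, it also remains open whether the step would persist on a core with a longer chain in place of the present one.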